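Cyanobenzyl ether in a lactone series silent for cytotoxicity

A few compounds are considered here, and "the series" means these few. Any claim that something is new, unique, unknown or untested is made for them only; others in the source may bear on it.

Compound 1 `CCOc1ccc(C(O)C2OC(=O)c3c(OC)cc(OC)cc32)cc1` in an ADME assay on RAW264.7 cells (Mus musculus) for cytotoxicity, read by MTT assay, with a stated time of 24 h, in the absence of a further agent (on this read-out lower numbers stand for stronger inhibition and higher numbers for weaker inhibition), gives > 40000 nM, a limit of the assay and not a number.
Compound 2 `CCCOc1ccc(C(O)C2OC(=O)c3c(OC)cc(OC)cc32)cc1` gives > 40000 nM, again a limit.
Compound 3 `COCCCOc1ccc(C(O)C2OC(=O)c3c(OC)cc(OC)cc32)cc1` gives > 40000 nM, also a limit.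

Compound 1 therefore stands at a limit only, and so do the other two: the limit of > 40000 nM in this assay, at which 3 of the 3 values shown sit. The steps a step that the two limits leave unreadable from compound 1 to compound 2, a step that the two limits leave unreadable from compound 1 to compound 3 and a step that the two limits leave unreadable from compound 2 to compound 3 run from limit to limit and have no readable size. Compound 4 `COc1cc(OC)c2c(c1)C(C(O)c1ccc(OCc3ccc(C#N)cc3)cc1)OC2=O` differs from compound 1 by 4-cyanophenyl in place of methyl on a saturated chain carbon bound to an oxygen on an aromatic ring. Among the measured compounds shown here, no measured step bears a readable size on this change, so the values shown give no direction and no size beyond the scatter to expect. Compound 4 is estimated to sit near the same limit, at 50000 nM with a range of 20000 nM to 150000 nM. The expected step is a step that the limit leaves unreadable from compound 1 to compound 4.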

Compound 4, half-maximal inhibitory concentration: > 40000 nM
Compound 4: no number, only a limit (the forecaster's own chance of this, stated with the estimate: 80%); the middle value lies beyond the limit too.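

In this assay no step between compound 4 and compound 1, compound 2 or compound 3 can be read, because all of them stand at a limit: the limit of > 40000 nM in this assay, at which 4 of the 4 values shown sit.

The compounds shown leave open how far each lies beyond that limit, and whether the 4-cyanobenzyl group changes cytotoxicity at all.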